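Swapping the Amine on the Amide Tail of Compound 1

The source may report more compounds than this note shows. Statements on the series, on what has been measured and on what is new or still open speak of the compounds shown alone.

Compound 1 `CCN(CC)CC(=O)Nc1ccc(-c2nc3cc(C(F)(F)F)ccc3n2C)cc1` was tested in an ADME assay on BHK cells (Mesocricetus auratus) for cytotoxicity, read by MTT assay, with a stated time of 96 h (a higher number here means that more compound is tolerated, a lower number that less compound is tolerated), where compound 1 gives 16000 nM. Compound 3 `CCN(CC)CC(=O)Nc1ccc(-c2nc3cc(C(F)(F)F)ccc3[nH]2)cc1` carries hydrogen in place of methyl on an aromatic nitrogen, and in this assay compound 3 gives 23000 nM; the step of a 1.4-fold higher number from compound 1 to compound 3 (0.16 log units; within the scatter) lies within the usual scatter. Compound 2 `CC(=O)Nc1ccc(-c2nc3cc([N+](=O)[O-])ccc3[nH]2)cc1` reached only a limit of the assay in this assay, namely > 100000 nM, so for compound 2 no number is known (the limit of > 100000 nM in this assay, at which 1 of the 3 values shown sits). Of the two numbers available, compound 1 has the lowest, and compound 3 stands nearest to it.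

The untested compound 4 `Cn1c(-c2ccc(NC(=O)CN3CCCC3)cc2)nc2cc(C(F)(F)F)ccc21` differs from compound 1 at one place: pyrrolidin-1-yl in place of diethylamino on a saturated chain carbon bound to a carbonyl carbon. Going by the values given here, no measured step touches this part of the molecule; the only measured step, a 1.4-fold higher number from compound 1 to compound 3 (0.16 log units; within the scatter), concerns a different position and stayed within the scatter. Hence no shift beyond the scatter is expected for compound 4 in this assay, that is, no change at the digits printed from compound 1 to compound 4 (within the scatter). Compound 4 is therefore estimated at 16000 nM, with a range from 6000 nM to 45000 nM.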

Compound 4, half-maximal cytotoxic concentration: 27000 nM
The estimate for compound 4 lay 1.7-fold (0.23 log units) below the measured number; measured number inside the range.
By their numbers in this assay, from the lowest: compounds 1, 3 and 4 (each within the scatter of the next). At a limit, above all of these: compound 2.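

Compound 1 and compound 4 have the same count of heavy atoms in this group, and the change simply closes the open diethylamino group into the pyrrolidin-1-yl ring. In this assay, going by these compounds alone, this gives a 1.7-fold higher number from compound 1 to compound 4 (0.23 log units; within the scatter), the first evidence that the amine on the amide tail can take this change without a shift beyond the usual scatter. Nothing measured here bears on why the step is so small.

The compounds shown leave open whether a piperidine or morpholine ring, a dimethylamino group, or a longer chain between the carbonyl and the amine would also stay within the scatter. They also leave open whether pyrrolidin-1-yl would behave the same way with hydrogen in place of methyl on the aromatic nitrogen, as in compound 3.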